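This account rests on a few compounds, and the source may have more. Where it says the series, first, only, none or still open, it means among the compounds named here.

In an ADME assay on microsomes from liver (Mus musculus) for metabolic stability, read by LC-MS, using NADPH, with a stated time of 60 min (on this read-out lower numbers stand for a less stable compound and higher numbers for a more stable compound), compound 1 `CC(C)(C)c1cc2c(Oc3ccccc3F)ncnc2s1` gives < 5%, which is a limit and not a number. Compound 2 `CC(C)(C)c1sc2ncnc(Oc3ccccc3F)c2c1-c1ccccc1` gives < 5%, also a limit. Compound 3 `CC(C)(C)c1sc2ncnc(Oc3ccccc3F)c2c1-c1ccc(F)cc1` gives < 5%, again a limit. Among the measured compounds shown here, the series so far therefore comes down to one entry: the limit of < 5% in this assay, at which 3 of the 3 values shown sit.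

Compound 4 `CC(C)(C)c1sc2ncnc(Oc3ccccc3OC(F)(F)F)c2c1-c1ccc(F)cc1` departs from compound 3 by trifluoromethoxy in place of fluoro on an aromatic carbon, ortho to a large group.

Three measured steps are available, and none has a size: a step that the two limits leave unreadable from compound 1 to compound 2, a step that the two limits leave unreadable from compound 1 to compound 3 and a step that the two limits leave unreadable from compound 2 to compound 3. None of them makes this exchange of fluoro for trifluoromethoxy. With a step that the two limits leave unreadable from compound 2 to compound 3 as the nearest measured change, the data give no ground to expect a shift in either direction in this assay. The estimated step, a step that the limit leaves unreadable from compound 3 to compound 4, is expected to stay within the scatter, and a further limit is the likeliest report. For compound 4 the expected value is 4%, with an estimated range from 1% to 12%.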

Compound 4, percent of the compound remaining: 5%
Beside the measured number, compound 4's estimate is 1 percentage points below it; measured number inside the range.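

In this assay the exchange of fluoro for trifluoromethoxy, on an aromatic carbon ortho to a large group, gives a number no lower from compound 3 to compound 4 (the limit leaves the size open). Among the compounds shown here, this is the first change that yields a number in place of a limit, although the size of the step stays open and no gain in stability can be claimed from it. The earlier steps cannot be read, and the series still rests largely on one limit: the limit of < 5% in this assay, at which 3 of the 4 values shown sit.

Going by these compounds, whether any group at this position moves the read-out clear of that limit stays open, and an amine or a carboxylic acid in place of trifluoromethoxy would put this to the test. On these data alone, whether trifluoromethoxy in place of fluoro also gives a readable number on compound 1 or compound 2 stays open as well.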